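Swapping a Hydroxyphenyl for a Fluorophenyl

The source may report more compounds than this note shows. Statements on the series, on what has been measured and on what is new or still open speak of the compounds shown alone.

Of the compounds shown here, two have so far been tested in a functional assay on HL-60 cells (Homo sapiens) for cytotoxicity, read by WST assay, with a stated time of 48 h; a higher number here means that more compound is needed for the effect, a lower number that less compound is needed. Compound 1 `CCCCOc1cccc(C[C@H]2C(=O)OC[C@@H]2Cc2ccccc2)c1` gives 26000 nM in this assay. Compound 2 `Oc1ccccc1C[C@H]1COC[C@@H]1Cc1ccc(Cl)c(Cl)c1`, which carries a dichlorinated aryl arm on its saturated core, gives 34000 nM in this assay. The gap between compound 1 and compound 2 lies within the usual scatter of repeated measurements, so the two stand side by side rather than in any order. Compound 3 `Fc1ccc(C[C@H]2COC[C@@H]2Cc2ccc(Cl)c(Cl)c2)cc1` is not yet measured. It differs from compound 2 in one place: 4-fluorophenyl in place of 2-hydroxyphenyl on a saturated chain carbon bound to a saturated ring carbon. Going by the values given here, no pair of measured compounds shows a change of this kind, so nothing here points to a direction for the number. The expected step from compound 2 to compound 3 in this assay is a 1.0-fold higher number from compound 2 to compound 3 (0.01 log units; within the scatter), that is, none beyond the scatter. Compound 3 is estimated at 35000 nM, with a range from 12000 nM to 100000 nM.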

Compound 3, half-maximal effective concentration: 43000 nM
Estimate against measurement, compound 3: 1.2-fold (0.09 log units) below; the measured number falls inside the stated range.
By their numbers in this assay, from the lowest: compounds 1, 2 and 3 (each within the scatter of the next).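

Going by these compounds alone, this is the first change measured at this position: on a saturated chain carbon bound to a saturated ring carbon, 4-fluorophenyl in place of 2-hydroxyphenyl gives, in this assay, a 1.3-fold higher number from compound 2 to compound 3 (0.10 log units; within the scatter). The group that leaves has 1 hydrogen-bond donor and 1 hydrogen-bond acceptor and the group that enters has neither, yet the number stays within the scatter, so this assay does not tell these two groups apart here. No measurement at hand offers a reason for this result.

On these data alone, whether an amine or a carboxylic acid on this ring, or a longer chain in place of it, would give a different number remains open. As far as these compounds go, it is also open whether any change at this position can move the number beyond the scatter at all.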